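The compounds below may be only part of what the source reports. "The series", "measured", "known", "first", "only" and "open" are said of these compounds alone.

Compound 1 `S=c1oc(-c2ccc3c(c2)OCCO3)nn1CNc1ccccc1` and compound 2 `S=c1oc(-c2ccc3c(c2)OCCO3)nn1CNc1cc(Cl)ccc1Cl` share one core and differ only in the aryl group on the amine nitrogen. In a functional assay, with a stated time of 6 min (on this read-out lower numbers stand for stronger inhibition and higher numbers for weaker inhibition), compound 1 gives 5140 nM, and compound 2 gives 5420 nM. The step of a 1.1-fold higher number from compound 1 to compound 2 (0.02 log units; within the scatter) thus shows that replacing phenyl with 2,5-dichlorophenyl left the read-out where it was. Of the two numbers shown, that of compound 1 is the lowest, a distinction without weight since compound 2 sits within the scatter of it. Compound 3 `O=[N+]([O-])c1ccccc1NCn1nc(-c2ccc3c(c2)OCCO3)oc1=S` departs from compound 1 by nitro in place of hydrogen on an aromatic carbon. Among the compounds with values here, the only measured step that bears on substitution of this phenyl, a 1.1-fold higher number from compound 1 to compound 2 (0.02 log units; within the scatter), lay within the scatter, and nothing measured speaks to a nitro group in particular. Compound 3 is therefore expected to give 5000 nM in this assay, between 2000 nM and 12500 nM. The expected step of a 1.0-fold lower number from compound 1 to compound 3 (0.01 log units; within the scatter) is accordingly estimated to stay within the scatter.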

Compound 3, half-maximal inhibitory concentration: 10900 nM
The estimate for compound 3 lay 2.2-fold (0.34 log units) below the measured number; the range from low to high includes it.
By their numbers in this assay, from the lowest: compounds 1, 2 and 3 (each within the scatter of the next, the first and the last beyond it).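

In this assay, within the data shown here, nitro on the phenyl ring, ortho to a large group, gives the first step at this aryl group that passes the scatter: a 2.1-fold higher number from compound 1 to compound 3 (0.33 log units; beyond the scatter) is a modest weakening of inhibition, so this part of the molecule does not tolerate every substituent equally. The two substituted aryl groups remain indistinguishable, as a 2.0-fold higher number from compound 2 to compound 3 (0.30 log units; within the scatter) stays within the scatter, so 2-nitrophenyl and 2,5-dichlorophenyl cannot be ranked against each other here. Nothing available accounts for the weakening seen with the nitro group.

As far as these compounds go, it remains open whether this weakening is particular to nitro or would also appear with other groups on this ring. An amine, a methoxy group or a carboxylic acid in place of the nitro group would help to settle that.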